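The source may hold more compounds than are shown below. What is called first, only, known or untested is meant among the compounds shown, and "the series" means these compounds.

In an ADME assay on MT4 cells (Homo sapiens) for cytotoxicity, read by MTT assay, with a stated time of 4 days (on this read-out lower numbers stand for higher toxicity in this test and higher numbers for lower toxicity in this test), compound 1 `CC(=O)Nc1ccc(O)c(C(=O)/C=C/c2cccc(F)c2)c1` gives 30100 nM and compound 2 `CC(=O)Nc1ccc2oc(-c3ccccc3)cc(=O)c2c1` gives 184000 nM as the higher of these two numbers, a gap that lies beyond the scatter. Compound 3 `COc1cccc(-c2cc(=O)c3cc(NC(C)=O)ccc3o2)c1` reads > 404000 nM as a limit of the assay and not as a number. Going by the values given here, compound 2 therefore stands highest among the actual numbers so far.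

Compound 4 `CC(=O)Nc1ccc2oc(-c3ccccc3F)cc(=O)c2c1` differs from compound 2 in one place. The change fluoro in place of hydrogen on an aromatic carbon is fluoro in place of hydrogen on an aromatic carbon, ortho to a large group, so that phenyl becomes 2-fluorophenyl. Among the compounds with values here, one measured step bears on this, though only loosely, since it also starts from compound 2 and replaces a hydrogen on an aromatic carbon, in that case with methoxy. It shows an at least 2.1-fold higher number from compound 2 to compound 3 (0.34 log units; beyond the scatter) and ends on a limit, so it gives a lower bound on its size and a direction, but it concerns a different group. For the fluoro change in this assay no step beyond the scatter is therefore expected, with any drift more likely upward, and the estimate is a 1.1-fold higher number from compound 2 to compound 4 (0.04 log units; within the scatter) for now. Compound 4 is thus estimated at 200000 nM within a range of 85000 nM to 420000 nM in this reading.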

Compound 4, half-maximal cytotoxic concentration: 205000 nM
Beside the measured number, compound 4's estimate is 1.0-fold (0.01 log units) below it; the range from low to high includes it.
By their numbers in this assay, from the lowest: compound 1; then compounds 2 and 4 (each within the scatter of the next). At a limit, above all of these: compound 3.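

In this assay, putting fluoro in place of hydrogen, so that phenyl becomes 2-fluorophenyl, gives a 1.1-fold higher number from compound 2 to compound 4 (0.05 log units; within the scatter). Going by these compounds alone, this single-atom replacement on an aromatic carbon, ortho to a large group, therefore yields no difference that can be told apart from the scatter, and it gives the first actual number for a compound carrying a group on this phenyl ring. The only earlier step on that ring, the methoxy change, was an at least 2.1-fold higher number from compound 2 to compound 3 (0.34 log units; beyond the scatter), and compound 3 reads as a limit and not as a number: the limit of > 404000 nM in this assay, at which 1 of the 4 values shown sits.

The compounds shown leave open whether a group other than fluoro on an aromatic carbon ortho to a large group, such as an amine, a carboxylic acid or a chloro group, would give a step beyond the scatter. They also leave open how large the methoxy step really is, and whether the same fluoro change would read alike on a phenyl ring that already carries another group.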